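This account rests on a few compounds, and the source may have more. Where it says the series, first, only, none or still open, it means among the compounds named here.

The account begins with compound 1 `COc1ccc(-c2cnc3nc(N)nc(N4CCC(C)CC4)c3n2)cc1OC`, which in a functional assay on cells (T-cell, Homo sapiens) for inhibition (a higher number here means a weaker inhibitor, a lower number a stronger inhibitor), gives 800 nM. Among the three measured compounds it holds the lowest number, yet compound 2 `COc1ccc(-c2cnc3nc(N)nc(N4CCN(Cc5ccccc5)CC4)c3n2)cc1OC`, giving 900 nM in this assay, lies within the usual scatter of it, so the two cannot be separated. Compound 3 `CCOc1ccc(-c2cnc3nc(N)nc(OC(C)C)c3n2)cc1`, which gives 10000 nM in this assay, stands furthest away, and that gap lies beyond the scatter. Compound 4 `COc1ccc(-c2cnc3nc(N)nc(OC(C)C)c3n2)cc1OC` is not yet measured. It differs from compound 1 in one place: isopropoxy in place of 4-methylpiperidin-1-yl on an aromatic carbon. Because compound 3 carries that same isopropoxy group and gives 10000 nM in this assay, a rise in the number is expected for compound 4, and the step of a 5.0-fold higher number from compound 1 to compound 4 (0.70 log units; beyond the scatter) is estimated to reach beyond the scatter. Compound 4 is therefore expected to give 4000 nM, within a range from 1500 nM to 12000 nM.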

Compound 4, half-maximal inhibitory concentration: 400 nM
Compound 4: the middle estimate sits 10-fold (1.00 log units) above what was measured; the whole stated range lies above it.
By their numbers in this assay, from the lowest: compounds 4, 1 and 2 (each within the scatter of the next, the first and the last beyond it); then compound 3.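

In this assay, replacing 4-methylpiperidin-1-yl with isopropoxy on this aromatic carbon gives a 2.0-fold lower number from compound 1 to compound 4 (0.30 log units; within the scatter), so the two groups cannot be separated here. The position therefore accepts a group with no ring and fewer heavy atoms, without any change that stands clear of the scatter. Nothing available explains why the two groups read alike. The compounds shown leave open whether an open-chain amine such as dimethylamino, or a longer alkoxy chain such as butoxy, would read the same at this position.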